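The source may hold more compounds than are shown below. What is called first, only, known or untested is meant among the compounds shown, and "the series" means these compounds.

Working notes on the series. Compound 1 `CN(C)c1ccc(C(=O)N2CCC(NS(=O)(=O)c3cc(S(=O)(=O)c4ccccc4)ccc3C(F)(F)F)CC2)cn1` gives 40 nM in an assay on isolated protein for displacement of a labelled ligand from secreted frizzled-related protein 1 (Homo sapiens), read by fluorescence polarization, with a stated time of 30 min; on this read-out higher numbers stand for weaker inhibition and lower numbers for stronger inhibition. Compound 2 `O=C(O)c1cccc(S(=O)(=O)N2CCC(NS(=O)(=O)c3cc(S(=O)(=O)c4ccccc4)ccc3C(F)(F)F)CC2)c1` gives 20 nM in this assay, the lowest of the two numbers, though the step of a 2.0-fold lower number from compound 1 to compound 2 (0.30 log units; within the scatter) lies within the scatter. Compound 3 `O=C(CC1CCNCC1)N1CCC(NS(=O)(=O)c2cc(S(=O)(=O)c3ccccc3)ccc2C(F)(F)F)CC1` carries the change (((piperidin-4-yl)methyl)carbonyl in place of (3-carboxyphenyl)sulfonyl on an amine nitrogen in a ring). Among the measured compounds shown here, the only measured step at this position bears on it loosely: it compares two groups each holding an aromatic ring, whereas the entering group holds none, so no step beyond the scatter is expected in this assay. Compound 3 is expected near 40 nM, range 10 nM to 200 nM. The estimated step is a 2.0-fold higher number from compound 2 to compound 3 (0.30 log units; within the scatter).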

Compound 3, half-maximal inhibitory concentration: 100 nM
Beside the measured number, compound 3's estimate is 2.5-fold (0.40 log units) below it; measured number inside the range.
By their numbers in this assay, from the lowest: compounds 2 and 1 (each within the scatter of the next); then compound 3.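

Going from the sulfonyl to the carbonyl series at this ring nitrogen, the change gives a 5.0-fold higher number from compound 2 to compound 3 (0.70 log units; beyond the scatter) in this assay and is the first step here beyond the scatter. With the carbonyl kept, (piperidin-4-yl)methyl in place of 6-(dimethylamino)pyridin-3-yl gives a 2.5-fold higher number from compound 1 to compound 3 (0.40 log units; beyond the scatter) and leaves compound 3 with the highest number of the series, by modest steps. No measurement at hand accounts for either step.

The step from compound 2 changes the linking group and the ring together, so their shares stay unseparated. A (3-carboxyphenyl)carbonyl group on the same nitrogen would divide them.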